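Extending the hydroxycarbamoyl chain in compound 4

The compounds below may be only part of what the source reports. "The series", "measured", "known", "first", "only" and "open" are said of these compounds alone.

Compound 1 `O=C(O)c1ccc2c(c1)no[n+]2[O-]` is the simplest member of this small series, and in a functional assay on HCT-116 cells (Homo sapiens) for inhibition, read by MTT assay, with a stated time of 48 h (a higher number here means a weaker inhibitor, a lower number a stronger inhibitor), compound 1 gives 55800 nM as its value. Compound 2 `O=C(CCCOC(=O)c1ccc2c(c1)no[n+]2[O-])NO` and compound 3 `O=C(CCCCOC(=O)c1ccc2c(c1)no[n+]2[O-])NO` keep the core of compound 1 but carry a chain that ends in hydroxycarbamoyl. In this assay compound 2 gives 2060 nM and compound 3 gives 2630 nM as their values. Compound 3 therefore stands level with compound 2, and both numbers lie far under that of compound 1.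

Compound 4 `O=C(CCCCCOC(=O)c1ccc2c(c1)no[n+]2[O-])NO` has not yet been measured. Going from compound 3 to compound 4 puts (hydroxycarbamoyl)methyl in place of hydroxycarbamoyl on a saturated chain carbon, four bonds along the chain from an oxygen next to a carbonyl group. The same kind of change has been measured only once, as a 1.3-fold higher number from compound 2 to compound 3 (0.11 log units; within the scatter) and that step lies within the scatter. One step is thin evidence, but it gives no reason to expect a shift beyond the scatter in this assay this time. The expected size of the change is a 1.1-fold lower number from compound 3 to compound 4 (0.04 log units; within the scatter) in this estimate. For compound 4 the estimated value is 2400 nM with an expected range from 1100 nM to 5000 nM in this assay once it is measured.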

Compound 4, half-maximal inhibitory concentration: 3360 nM
Estimate against measurement, compound 4: 1.4-fold (0.15 log units) below; measured number inside the range.
By their numbers in this assay, from the lowest: compounds 2, 3 and 4 (each within the scatter of the next); then compound 1.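

Compound 4 adds a second step of the same kind at this position, and in this assay it gives a 1.3-fold higher number from compound 3 to compound 4 (0.11 log units; within the scatter), so the small size of the earlier step was not a one-off. The wider comparison matters more: taking the chain through both added carbons, with 2-(hydroxycarbamoyl)ethyl in place of hydroxycarbamoyl, gives a 1.6-fold higher number from compound 2 to compound 4 (0.21 log units; within the scatter), so even the two steps combined do not separate compounds 2, 3 and 4 in this assay, and none of the three goes against that reading. Nothing shown here accounts for this lack of separation.

The compounds shown leave open whether a chain longer than the one in compound 4, or one shorter than the one in compound 2, would still stay level with these three. They also leave open how the same chains would behave if they ended in a carboxylic acid or an amine instead of hydroxycarbamoyl, so the part played by that end group cannot be judged from these compounds alone.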